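Vero cytotoxicity notes: the unsubstituted phenyl amide of compound 3

This account rests on a few compounds, and the source may have more. Where it says the series, first, only, none or still open, it means among the compounds named here.

Measured in an ADME assay on Vero cells (Chlorocebus sabaeus) for cytotoxicity, read by resazurin assay, with a stated time of 3 days; on this read-out lower numbers stand for stronger inhibition and higher numbers for weaker inhibition:
- compound 1 `COc1ccc(C(=O)Nc2cc3nc(C4CCCCC4)[nH]c3cc2N(C)C)cc1` gives > 100 ug/mL, which is a limit of the assay.
- compound 2 `CCc1ccc(C(=O)Nc2cc3nc(C4CCCCC4)[nH]c3cc2N(C)C)cc1` gives > 100 ug/mL, which is a limit of the assay.
- compound 3 `CN(C)c1cc2[nH]c(C3CCCCC3)nc2cc1NC(=O)c1ccc(F)cc1F` gives > 100 ug/mL, which is a limit of the assay.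

Compound 3 stands only at a limit in this assay; no number is known for it, and the two further values shown are limits as well, as the limit of > 100 ug/mL in this assay, at which 3 of the 3 values shown sit, states. The steps a step that the two limits leave unreadable from compound 1 to compound 2, a step that the two limits leave unreadable from compound 1 to compound 3 and a step that the two limits leave unreadable from compound 2 to compound 3 are all unreadable because both ends of each share (the limit of > 100 ug/mL in this assay, at which 3 of the 3 values shown sit). Within the series, then, no change at the amide aryl group has yet produced a readable value.

Compound 4 `CN(C)c1cc2[nH]c(C3CCCCC3)nc2cc1NC(=O)c1ccccc1` differs from compound 3 by phenyl in place of 2,4-difluorophenyl on a carbonyl carbon. The measured steps that bear on this change are the three unreadable ones above, none of which shows any readable size in this assay. The expected step is therefore none beyond the scatter, and most likely again a limit: a step that the limit leaves unreadable from compound 3 to compound 4. Compound 4 is estimated at 150 ug/mL, with a range from 70 ug/mL to 400 ug/mL.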

Compound 4, half-maximal inhibitory concentration: > 100 ug/mL
Compound 4: no number, only a limit; the forecaster's own chance of this, stated with the estimate: 85%; the middle value is on the limit's open side.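

No new step can be read in this assay between compound 4 and compound 1, compound 2 or compound 3, because all four share one limit: the limit of > 100 ug/mL in this assay, at which 4 of the 4 values shown sit. The compounds shown leave open where any true value lies, and whether the amide aryl group affects cytotoxicity at all.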